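Hydroxy versus methoxy on the chloro-substituted phenyl arm

The source may hold more compounds than are shown below. What is called first, only, known or untested is meant among the compounds shown, and "the series" means these compounds.

Measured so far:
compound 1 `O=C(Nc1cccc(-n2cc(-c3ccncc3)c(-c3cc(O)cc(Cl)c3)n2)c1)Nc1ccc(Cl)c(C(F)(F)F)c1`: 13.8%
compound 2 `COc1cc(Cl)cc(-c2nn(-c3cccc(NC(=O)Nc4ccc(Cl)c(C(F)(F)F)c4)c3)cc2-c2ccncc2)c1`: -29.1%
compound 3 `O=C(Nc1cccc(-n2cc(-c3ccncc3)c(-c3cc(O)cc(Cl)c3)n2)c1)c1cc(C(F)(F)F)cc(C(F)(F)F)c1`: 32.1%

In a functional assay on RPMI-8226 cells (Homo sapiens) for inhibition, read by sulforhodamine B assay, with a stated time of 48 h, tested at 10 uM (on this read-out higher numbers stand for a weaker effect at the one concentration tested and lower numbers for a stronger effect), compound 1 gives 13.8%, while compound 2 gives -29.1%. The change between them, (methyl in place of hydrogen on an oxygen on an aromatic ring), gave a number 42.9 percentage points lower from compound 1 to compound 2 (beyond the scatter). Compound 3 gives 32.1%, the highest of the three numbers; how its core differs from that of compound 1 is not broken down here.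

Compound 4 `COc1cc(Cl)cc(-c2nn(-c3cccc(NC(=O)c4cc(C(F)(F)F)cc(C(F)(F)F)c4)c3)cc2-c2ccncc2)c1` carries the same change on the core of compound 3, (methyl in place of hydrogen on an oxygen on an aromatic ring), at the same place as before. Among the compounds with values here, since only one example of this change has been measured, the size of a number 42.9 percentage points lower from compound 1 to compound 2 (beyond the scatter) is the sole basis, and the expected step is a number 37.1 percentage points lower from compound 3 to compound 4 (beyond the scatter), taken somewhat smaller than the measured one to allow for a single precedent. Compound 4 is therefore expected to give about -5% in this assay, within roughly -35% to 25%.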

Compound 4, a percentage reported as activity, at one concentration (the size of the read-out at that concentration, not a potency): 43.6%
Estimate against measurement, compound 4: 48.6 percentage points below, and the stated range ends below it.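

Working from the hydroxy to methoxy change on the 3-chloro-5-hydroxyphenyl arm, this assay gives a number 11.5 percentage points higher from compound 3 to compound 4 (beyond the scatter), a step opposite in direction to the earlier one. The two steps do not agree: the same change on two cores in this assay, a number 42.9 percentage points lower (beyond the scatter) from compound 1 to compound 2 and a number 11.5 percentage points higher (beyond the scatter) from compound 3 to compound 4, 54.4 percentage points apart, beyond the scatter of two such steps. The effect of this change therefore does not carry from the core of compound 1 to the core of compound 3, although two pairs cannot show which difference between the cores is responsible or how the change would behave on a further core.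

Left open is whether an ethyl group or a longer chain on that oxygen, or an amine in place of the hydroxy, would follow either step. Also open, from the compounds shown here alone, is whether the opposite steps would hold across a range of concentrations.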